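Lipophilicity of a pyrazole amide series: benzyl amide estimate

The compounds below may be only part of what the source reports. "The series", "measured", "known", "first", "only" and "open" are said of these compounds alone.

Compound 1 `Cc1cc(C(=O)Nc2cccc(F)c2)nn1Cc1cc(Cl)ccc1OCc1ccccc1`: 2.8
Compound 2 `Cc1cc(C(=O)Nc2c(F)cccc2F)nn1Cc1cc(Cl)ccc1OCc1ccccc1`: 3.7

In a physicochemical assay for lipophilicity, at pH 7.4 (on this read-out lower numbers stand for lower lipophilicity and higher numbers for higher lipophilicity), compound 2 stands highest of the two numbers, with compound 1 the nearest value. Among the measured compounds shown here, the one measured step, a number 0.90 log units higher from compound 1 to compound 2 (beyond the scatter), changes only the fluorine pattern on the phenyl. Compound 3 `Cc1cc(C(=O)NCc2ccccc2)nn1Cc1cc(Cl)ccc1OCc1ccccc1` differs from compound 2 as follows: benzyl in place of 2,6-difluorophenyl on an amide-type nitrogen. For the measured compounds named here, no measured step covers this change, so the expectation rests on the change itself. For compound 3 a modest decrease, a number 0.70 log units lower from compound 2 to compound 3 (beyond the scatter), is expected. Compound 3 is therefore estimated at 3, in the range 2.4 to 3.6.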

Compound 3, distribution coefficient: > 3.7
Compound 3: no number, only a limit (the forecaster's own chance of this, stated with the estimate: 5%); at least 0.70 log units between middle value and limit.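

In this assay compound 3 gives no number, only a limit: the limit of > 3.7 in this assay, at which 1 of the 3 values shown sits.

On the amide-type nitrogen, benzyl in place of 3-fluorophenyl gives a number at least 0.90 log units higher from compound 1 to compound 3 (beyond the scatter), and benzyl in place of 2,6-difluorophenyl gives a number no lower from compound 2 to compound 3 (the limit leaves the size open). The earlier compounds shown here varied only the fluorine pattern on a phenyl, whereas this change puts a benzyl on the same nitrogen, and the read-out does not come down.

On these data alone, how far compound 3 lies past compound 2 stays open. So does where a chain ending in an amine or a carboxylic acid on this nitrogen would fall in this assay.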